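From Hexyl to 4-Bromophenyl on an Amide-Type Nitrogen

The source may report more compounds than this note shows. Statements on the series, on what has been measured and on what is new or still open speak of the compounds shown alone.

Among the measured compounds shown here, compound 1 `CCCCCCNC(=S)N/N=C1\C(=O)Nc2ccc([N+](=O)[O-])cc21` stands highest of the two numbers so far in a functional assay on the whole organism for inhibition, with Lemna aequinoctialis as the target, tested at 10 ug/mL (a lower number here means less inhibition of growth, a higher number more inhibition of growth at the concentration tested), giving 25%. Compound 2 `COc1ccc(NC(=S)N/N=C2\C(=O)Nc3ccc([N+](=O)[O-])cc32)cc1` gives 10%. For the measured compounds named here, the only measured step, a number 15 percentage points lower from compound 1 to compound 2 (beyond the scatter), went with 4-methoxyphenyl in place of hexyl on the same amide-type nitrogen. Compound 3 `O=C1Nc2ccc([N+](=O)[O-])cc2/C1=N/NC(=S)Nc1ccc(Br)cc1` carries a related change: 4-bromophenyl in place of hexyl on an amide-type nitrogen. That precedent bears directly on it, and because compound 2 showed a number 15 percentage points lower from compound 1 to compound 2 (beyond the scatter), a lowering of comparable size is expected for compound 3, a number 11 percentage points lower from compound 1 to compound 3 (beyond the scatter). Compound 3 is therefore estimated at 14%, with a range from 3% to 30%.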

Compound 3, percent growth inhibition at one concentration: 10%
Compound 3: middle estimate off by 4 percentage points, on the high side, and the stated range covers the measured number.
By their numbers in this assay, from the lowest: compounds 2 and 3 (each within the scatter of the next); then compound 1.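

In this assay the step of a number 15 percentage points lower from compound 1 to compound 3 (beyond the scatter) matches the earlier lowering in size, so on this amide-type nitrogen the lower number now goes with 4-bromophenyl as well as 4-methoxyphenyl in place of hexyl. Bromo in place of methoxy on the aromatic carbon gives no change at the digits printed from compound 2 to compound 3 (within the scatter) and so does not separate these two compounds. No measurement here accounts for the lowering.

Open, as far as these compounds go, is whether a longer chain or a benzyl group on this nitrogen would stay near compound 1 or fall near compound 2 and compound 3. Also open, from the compounds shown here alone, is what an amine or a carboxylic acid on the aromatic carbon would do to the number.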